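The compounds below may be only part of what the source reports. "The series", "measured", "known", "first", "only" and "open" are said of these compounds alone.

Compound 2, with the structure `O=C(NO)c1ccc(NCc2nc(-c3ccc(Cl)c(Cl)c3)nn2-c2ccccc2)cc1`, gives the lower of the two measured numbers in an assay on Sf9 cells for inhibition of protein deacetylase HDAC6 (Homo sapiens), read by fluorescence, with a stated time of 40 min, tested at 100 nM; on this read-out higher numbers stand for more inhibition at the one concentration tested (going by the name of the read-out) and lower numbers for less inhibition. In that assay compound 2 gives 34.5%, while compound 1, with the structure `O=C(NO)c1ccc(NCc2nc(-c3cc4ccccc4s3)nn2-c2ccccc2)cc1`, gives 65.5%. Within the data shown here, the only measured step runs a number 31 percentage points lower from compound 1 to compound 2 (beyond the scatter), where a bicyclic aromatic group gave way to a chlorinated phenyl ring.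

Compound 3, with the structure `Cc1ccc(-c2nc(CNc3ccc(C(=O)NO)cc3)n(-c3ccccc3)n2)o1`, has not yet been measured. It differs from compound 2 in one place: 5-methylfuran-2-yl in place of 3,4-dichlorophenyl on an aromatic carbon. The group that enters is smaller than the one that leaves and carries one ring oxygen as a hydrogen-bond acceptor. Among the measured compounds shown here, only the step from compound 1 to compound 2 bears on this change, and it shows that swapping the group at this position can move the read-out well beyond the scatter. With one bicyclic group high and one chlorinated phenyl low, there is no direct guide for a five-membered heteroaromatic ring here, so the expected step of a number 5.5 percentage points higher from compound 2 to compound 3 (within the scatter) is kept modest. Compound 3 is therefore estimated to give 40%, within a range from 20% to 62%.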

Compound 3, a percentage reported as inhibition, at one concentration (the size of the read-out at that concentration, not a potency): 60.7%
Compound 3: middle estimate off by 20.7 percentage points, on the low side, and the stated range covers the measured number.
By their numbers in this assay, from the lowest: compound 2; then compounds 3 and 1 (each within the scatter of the next).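

In this assay, placing 5-methylfuran-2-yl on this aromatic carbon gives a number 26.2 percentage points higher from compound 2 to compound 3 (beyond the scatter), which shows that the low number of compound 2 does not hold for every single-ring group here. Set against 1-benzothiophen-2-yl, the same group gives a number 4.8 percentage points lower from compound 1 to compound 3 (within the scatter), so a single five-membered aromatic ring and the bicyclic group cannot be told apart in this read-out. Among these three compounds, a bicyclic group is therefore not needed for the higher numbers, and compound 2 alone stands apart.

Still open, on these data alone, is what a plain furan-2-yl without the methyl, an unsubstituted phenyl or a single chlorine on the phenyl ring would give at this position. Nothing shown here explains why 3,4-dichlorophenyl stands apart from the other two groups.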